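Swapping an Iodoethenyl Arm for a Bulky Alkyne

This account rests on a few compounds, and the source may have more. Where it says the series, first, only, none or still open, it means among the compounds named here.

Measured compounds:
compound 1 `O=c1[nH]c(=O)n([C@H]2C[C@H](O)[C@@H](CO)O2)cc1/C=C/I` gives 63900 nM in an ADME assay on L1210/0 cells (Mus musculus) for cytotoxicity, with a stated time of 48 h; a higher number here means a weaker inhibitor, a lower number a stronger inhibitor.
compound 2 `Nc1ncnc2c1ncn2[C@@H]1C[C@@H]2COC[C@H]2[C@H]1CO` sits at a limit of this assay, > 200000 nM.

Within the data shown here, compound 1 is the only compound with a plain number in this assay. The value shown for compound 2 is a limit of the assay and not a number (the limit of > 200000 nM in this assay, at which 1 of the 2 values shown sits). Compound 3 `CC(C)(C)C#Cc1cn([C@H]2C[C@H](O)[C@@H](CO)O2)c(=O)[nH]c1=O` has not yet been measured. Among the measured compounds shown here, it keeps the core of compound 1; the one change is 3,3-dimethylbut-1-yn-1-yl in place of 2-iodoethenyl on an aromatic carbon. For the measured compounds named here, no pair of measured compounds differs in only one place, so no measured step gives a scale for this change. The expectation is a step from compound 1 to compound 3 of a 1.4-fold higher number from compound 1 to compound 3 (0.15 log units; within the scatter) in this assay, no larger than the usual scatter, with a slight lean toward weaker inhibition. Compound 3 is therefore estimated at 90000 nM, with a range from 25000 nM to 300000 nM.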

Compound 3, half-maximal inhibitory concentration: > 200000 nM
Compound 3: a limit, no number (the forecaster's own chance of this, stated with the estimate: 30%); middle value at least 2.2-fold (0.34 log units) from the limit.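

In this assay, among these compounds, the change at this aromatic carbon gives the first step that can be read for this position, an at least 3.1-fold higher number from compound 1 to compound 3 (0.49 log units; beyond the scatter), and it lies beyond the scatter. The position is therefore not indifferent to what it carries: 3,3-dimethylbut-1-yn-1-yl goes with weaker inhibition than 2-iodoethenyl. Compound 3 gives a limit and not a number, so the step has a lower bound but no known full size: the limit of > 200000 nM in this assay, at which 2 of the 3 values shown sit.

This single pair cannot separate the roles of the triple bond, the branched end of the chain and the departure of iodine. From the compounds shown here alone, how a 2-bromoethenyl arm or an unbranched hex-1-yn-1-yl chain would behave at the same carbon remains open.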